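The source may hold more compounds than are shown below. What is called first, only, known or untested is meant among the compounds shown, and "the series" means these compounds.

Working notes on a small series sharing one core, followed in a functional assay on MCF7 cells (Homo sapiens) for cytotoxicity, read by sulforhodamine B assay, with a stated time of 48 h; on this read-out lower numbers stand for higher toxicity in this test and higher numbers for lower toxicity in this test. Compound 1 `O=C1CC(c2ccc([N+](=O)[O-])cc2)Nc2c(Br)cc(Br)cc21` carries a nitro group. In this assay compound 1 gives > 100000 nM, which is a limit of the assay and not a number. Compound 2 `O=C1CC(c2ccc(O)cc2)Nc2c(Br)cc(Br)cc21` has hydroxy in place of nitro. In this assay compound 2 gives > 100000 nM, again a limit of the assay rather than a measured number. The step that the two limits leave unreadable from compound 1 to compound 2 is therefore unreadable. Where compound 2 stands can only be told as a limit; the other value shown sits at the same limit, as recorded in the limit of > 100000 nM in this assay, at which 2 of the 2 values shown sit.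

Compound 3 `CN(C)c1ccc(C2CC(=O)c3cc(Br)cc(Br)c3N2)cc1` is not yet measured. It differs from compound 2 by dimethylamino in place of hydroxy on an aromatic carbon. Within the data shown here, the only measured step, a step that the two limits leave unreadable from compound 1 to compound 2, bears on an exchange at that same aromatic carbon, but two limits leave its size unreadable, so no step beyond the scatter can be expected in this assay. The expected step that the limit leaves unreadable from compound 2 to compound 3 is an estimate only. Compound 3 is accordingly expected near 150000 nM, with an estimated range of 40000 nM to 500000 nM, most likely reported again as a limit.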

Compound 3, concentration lethal to 50% of the cells: > 100000 nM
Compound 3: no number, only a limit; the forecaster's own chance of this, stated with the estimate: 80%; the middle value is on the limit's open side.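

In this assay compound 3 gives > 100000 nM, a limit of the assay and not a number. Among these compounds, no step linking compound 3 with compound 1 or compound 2 can be read: the limit of > 100000 nM in this assay, at which 3 of the 3 values shown sit. Left open is whether any group on that aromatic carbon of the shared core gives a readable value in this assay, and how far nitro, hydroxy and dimethylamino actually differ.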